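The source may report more compounds than this note shows. Statements on the series, on what has been measured and on what is new or still open speak of the compounds shown alone.

Compound 1 `COc1ccccc1Nc1nc(-c2cccc(F)c2)nc2ccc(F)cc12` was tested in a functional assay on COLO 205 cells (Homo sapiens) for cytotoxicity, read by MTT assay, with a stated time of 48 h; a higher number here means a weaker inhibitor, a lower number a stronger inhibitor. In this assay compound 1 gives > 50000 nM, which is a limit of the assay rather than a number. Compound 2 `Fc1cccc(Nc2nc(-c3cccc(F)c3)nc3ccc(F)cc23)c1` shares the core and carries 3-fluorophenyl in place of 2-methoxyphenyl on a nitrogen on an aromatic ring. In this assay compound 2 gives > 50000 nM, again only a limit. The step that the two limits leave unreadable from compound 1 to compound 2 therefore cannot be read in size, because of the limit of > 50000 nM in this assay, at which 2 of the 2 values shown sit. Compound 3 `Fc1cccc(-c2nc(Nc3ccc(Cl)cc3)c3cc(F)ccc3n2)c1` has not yet been measured; it differs from compound 1 by 4-chlorophenyl in place of 2-methoxyphenyl on a nitrogen on an aromatic ring. Going by the values given here, the only comparable step, the one to compound 2, shows no readable size, so for compound 3 no direction beyond the scatter can be expected. Compound 3 is therefore expected to give about 60000 nM, between 20000 nM and 200000 nM, most likely again reported only as a limit. The step expected is thus a step that the limit leaves unreadable from compound 1 to compound 3.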

Compound 3, half-maximal inhibitory concentration: 32600 nM
For compound 3 the middle estimate is 1.8-fold (0.26 log units) above the measured one; the range from low to high includes it.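

At this place, on a nitrogen on an aromatic ring, 4-chlorophenyl gives the first result in this assay that is a number and not a limit, so a change here can now be given a floor for its size. Measured against 2-methoxyphenyl, the change is an at least 1.5-fold lower number from compound 1 to compound 3 (0.18 log units; that floor lies within the scatter), and measured against 3-fluorophenyl, it is an at least 1.5-fold lower number from compound 2 to compound 3 (0.18 log units; that floor lies within the scatter). Neither floor alone shows a change beyond the scatter, and the earlier step stays unreadable because both earlier compounds stand at a limit: the limit of > 50000 nM in this assay, at which 2 of the 3 values shown sit.

As far as these compounds go, the true size of either step remains open, as compound 1 and compound 2 have no exact values. Also open, from the compounds shown here alone, is whether a different group at this place, such as 4-aminophenyl or a phenyl ring carrying a carboxylic acid, would give a clearly lower number than compound 3.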